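Halophenyl exchange on the saturated ring carbon

A few compounds are considered here, and "the series" means these few. Any claim that something is new, unique, unknown or untested is made for them only; others in the source may bear on it.

Compound 1 `Clc1cccc(C2CC(c3ccc4c(c3)OCCO4)=NN2c2ccccc2)c1` is the reference point. For the measured compounds named here, in a functional assay on WM 266-4 cells (Homo sapiens) for antiproliferative activity, read by MTT assay, with a stated time of 24 h (on this read-out higher numbers stand for weaker inhibition of growth and lower numbers for stronger inhibition of growth), compound 1 gives 1750 nM, the lowest of the two numbers available, but its only neighbour, compound 2 `Ic1ccc(C2CC(c3ccc4c(c3)OCCO4)=NN2c2ccccc2)cc1`, gives 3470 nM, and the step of a 2.0-fold higher number from compound 1 to compound 2 (0.30 log units; within the scatter) lies within the scatter, so no order between these two can be claimed. Going by the values given here, that step, 4-iodophenyl in place of 3-chlorophenyl on a saturated ring carbon, is the single comparison available.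

Compound 3 `Brc1ccc(C2CC(c3ccc4c(c3)OCCO4)=NN2c2ccccc2)cc1` has not been measured. Its difference from compound 1 is 4-bromophenyl in place of 3-chlorophenyl on a saturated ring carbon. Among the compounds with values here, the one measured step that bears on it is a 2.0-fold higher number from compound 1 to compound 2 (0.30 log units; within the scatter), which stayed within the scatter, and nothing here points to a larger effect for compound 3. The expected step is therefore a 1.5-fold higher number from compound 1 to compound 3 (0.17 log units; within the scatter), within the scatter. Compound 3 is accordingly estimated to give 2600 nM in this assay, with a range from 1200 nM to 5500 nM.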

Compound 3, concentration for 50% growth inhibition: 3010 nM
Estimate against measurement, compound 3: 1.2-fold (0.06 log units) below, and the stated range covers the measured number.
By their numbers in this assay, from the lowest: compounds 1, 3 and 2 (each within the scatter of the next).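

In this assay the new compound gives a second exchange of the halophenyl group on the saturated ring carbon, and both steps stay within the scatter (a 1.7-fold higher number from compound 1 to compound 3 (0.24 log units; within the scatter)) and (a 1.2-fold lower number from compound 2 to compound 3 (0.06 log units; within the scatter)). The second step, bromo in place of iodo on an aromatic carbon, changes only the halogen, so 3-chlorophenyl, 4-bromophenyl and 4-iodophenyl at this carbon cannot be put in any order, and no effect of the halogen or of its place on the phenyl ring can be read. No measured evidence bears on these steps.

Open, as far as these compounds go, is whether any group at this carbon moves the number beyond the scatter, for example unsubstituted phenyl, a phenyl carrying an amine or a carboxylic acid, or a pyridine ring. Open too, from the compounds shown here alone, is whether changes elsewhere on the shared core matter more than this exchange.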